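A few compounds are considered here, and "the series" means these few. Any claim that something is new, unique, unknown or untested is made for them only; others in the source may bear on it.

Compound 1 `Cc1c(OCCCCOc2ccc(C(=O)O)cc2)ccc(C(=O)CC2CCCC2)c1C` and compound 2 `Cc1c(OCCCCOc2ccc(C(=O)O)cc2)ccc(C(=O)CC(C)C)c1C` share one core, while compound 3 `Cc1ccc(C(=O)O)cc1OCCCCOc1ccc(C(=O)CC(C)C)c(O)c1C` and compound 4 `Cc1ccc(C(=O)O)cc1OCCCCOc1ccc(C(=O)CC2CCCC2)c(O)c1C` share another; the difference between the two cores is not broken down here. In an assay on HEK293 cells for positive allosteric modulation of metabotropic glutamate receptor 2 (Rattus norvegicus), read by thallium flux, with a stated time of 2.5 min (on this read-out lower numbers stand for smaller maximal responses and higher numbers for larger maximal responses), compound 1 gives 16.2% and compound 2 gives 19%, whereas compound 3 gives 76.9%, beyond the scatter from both of the others. Within the first core one change has been measured (cyclopentyl in place of isopropyl on a saturated chain carbon bound to a carbonyl carbon), and it made a step of a number 2.8 percentage points lower from compound 2 to compound 1 (within the scatter). Compound 4 carries the same change on the core of compound 3 (cyclopentyl in place of isopropyl on a saturated chain carbon bound to a carbonyl carbon), at the same place. Because this change earlier gave a number 2.8 percentage points lower from compound 2 to compound 1 (within the scatter), compound 4 is expected to stay close to compound 3, with an estimated step of a number 2.9 percentage points lower from compound 3 to compound 4 (within the scatter). Compound 4 is therefore estimated at 74%, likely between 55% and 90%.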

Compound 4, largest response reached (reported as percent of maximum), in percent of the reference or control that the assay uses: 67.5%
Compound 4: middle estimate off by 6.5 percentage points, on the high side; low and high end bracket the measured number.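

In this assay cyclopentyl in place of isopropyl gives a number 9.4 percentage points lower from compound 3 to compound 4 (within the scatter), so on this core too the swap leaves the maximal response within the usual scatter. Set beside the earlier step, the change carries over from one core to the other with no detectable difference: the same change on two cores in this assay, a number 2.8 percentage points lower (within the scatter) from compound 2 to compound 1 and a number 9.4 percentage points lower (within the scatter) from compound 3 to compound 4, 6.6 percentage points apart, within the scatter of two such steps. This holds only for these two cores and this one read-out; it does not show that other cores would respond alike, and steps this small cannot separate a slight real loss from scatter.

For the compounds shown here, only two all-carbon groups are compared at this place, so an amine or a carboxylic acid on the saturated chain carbon remains open. Which part of the difference between the two cores goes with their higher or lower responses also remains open.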